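Replacing 4-chlorophenyl in compound 3

The source may report more compounds than this note shows. Statements on the series, on what has been measured and on what is new or still open speak of the compounds shown alone.

Measured in a functional assay on K-562R cells (Homo sapiens) for cytotoxicity, read by MTT assay, with a stated time of 48 h; on this read-out higher numbers stand for weaker inhibition and lower numbers for stronger inhibition
compound 1 `COc1ccc(-c2c[nH]c(=O)n2-c2cc(OC)c(OC)c(OC)c2)cc1[N+](=O)[O-]` - > 50000 nM (a limit)
compound 2 `COc1ccc(-c2cn(C(=O)Nc3cc(OC)c(OC)c(OC)c3)c(=O)n2-c2cc(OC)c(OC)c(OC)c2)cc1` - 3500 nM
compound 3 `COc1cc(-n2c(-c3ccc(Cl)cc3)cn(C(C)=O)c2=O)cc(OC)c1OC` - "not determined" (no result reported)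

Compound 3 has no place on the scale of this assay, since no result was reported for it. For compound 1 the figure > 50000 nM is a limit. Compound 4 `COc1ccc(-c2cn(C(C)=O)c(=O)n2-c2cc(OC)c(OC)c(OC)c2)cc1N` is still unmeasured. Its change is 3-amino-4-methoxyphenyl in place of 4-chlorophenyl on an aromatic carbon, with 3-amino-4-methoxyphenyl in place of 4-chlorophenyl on an aromatic carbon. Among the compounds with values here, compound 3 offers no number, so no step in this assay can be sized or given a direction. Within the data shown here, the expectation rests instead on compound 2 at 3500 nM, the only exact number available. For compound 4 the expected value is 2500 nM (estimated range 200 nM to 30000 nM).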

Compound 4, half-maximal inhibitory concentration: 49300 nM
The estimate for compound 4 lay 20-fold (1.29 log units) below the measured number, outside the stated range (above it).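

No step can be read between compound 3 and compound 4: compound 3 has no reported result, while compound 4 gives 49300 nM. The compounds shown leave open how 3-amino-4-methoxyphenyl compares with 4-chlorophenyl on the shared core.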